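This account rests on a few compounds, and the source may have more. Where it says the series, first, only, none or still open, it means among the compounds named here.

Three close relatives of one shared core have been measured for how strongly they switch on the receptor in a functional assay on isolated protein for agonist activity at Glucose-dependent insulinotropic receptor (Rattus norvegicus), read by HTRF and cAMP accumulation; a lower number here means a smaller maximal response, a higher number a larger maximal response. Compound 1 `CC(C)(C)OC(=O)N1CCC(O[C@H]2CC[C@H](Oc3ccc(S(C)(=O)=O)cc3)CC2)CC1` reaches 120% in this assay. Compound 2 `CC(C)(C)OC(=O)N1CCC(O[C@H]2CC[C@H](Oc3ccc(C#N)cc3)CC2)CC1` reaches 106%. Within the data shown here, the single one-place step measured so far, a number 14 percentage points lower from compound 1 to compound 2 (beyond the scatter), shows that swapping the group on the aromatic ring can move the maximal response noticeably. Compound 3 `CC(C)OC(=O)N1CCC(O[C@H]2CC[C@H](Oc3ccc(S(C)(=O)=O)nc3)CC2)CC1` reaches 125% in this assay; its number and that of compound 1 lie within the usual scatter of each other, whereas compound 2 lies beyond the scatter of compound 3, so compound 3 sits with compound 1 among the stronger responders.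

Compound 4 `Cc1nc(S(C)(=O)=O)ccc1O[C@H]1CC[C@H](OC2CCN(C(=O)OC(C)C)CC2)CC1` has not yet been measured. It differs from compound 3 by methyl in place of hydrogen on an aromatic carbon. Among the measured compounds shown here, no measured step involves adding a methyl group, so the one step in hand, which exchanged the methylsulfonyl group itself, speaks to this change only indirectly, and the methylsulfonyl group is kept in compound 4. The expectation is therefore a change of a number 3 percentage points lower from compound 3 to compound 4 (within the scatter), that is, nothing beyond the scatter. Compound 4 is estimated to reach 122% in this assay, within a range from 105% to 135%.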

Compound 4, largest response reached (Emax), in percent of the reference or control that the assay uses: 114%
For compound 4 the middle estimate is 8 percentage points above the measured one; the measured number falls inside the stated range.
By their numbers in this assay, from the lowest: compounds 2, 4, 1 and 3 (each within the scatter of the next, the first and the last beyond it).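

In this assay, methyl in place of hydrogen on an aromatic carbon, next to the ring nitrogen and ortho to a large group, gives a number 11 percentage points lower from compound 3 to compound 4 (beyond the scatter). Among these compounds, this shows that the maximal response can move even when the methylsulfonyl group stays in place, whereas the only earlier step changed that group itself. It also shows that adding just one heavy atom at this position is enough for a shift beyond the usual scatter, although no measurement here explains why the response moves in this direction.

The compounds shown leave open whether the response at this position depends on the methyl group specifically, or whether an ethyl group, a methoxy group or a fluorine atom would give a similar result. They also leave open whether the same methyl would have a comparable effect alongside a nitrile in place of the methylsulfonyl group, or on a different aromatic carbon of the ring.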